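This account rests on a few compounds, and the source may have more. Where it says the series, first, only, none or still open, it means among the compounds named here.

Within the data shown here, compound 2 `Cn1nccc1-c1cccc2c1CCCN2c1ccc(C#N)c(C(F)(F)F)c1` is one of two compounds measured in a functional assay on PC-3 cells (Homo sapiens) for antiproliferative activity, read by CCK-8 assay, with a stated time of 6 days (a higher number here means a weaker inhibitor, a lower number a stronger inhibitor), where compound 2 gives 9800 nM. The other is compound 1 `N#Cc1ccc(N2CCCc3c(-c4cccnc4)cccc32)cc1C(F)(F)F`, which in this assay gives 7970 nM; the two differ by a 1.2-fold higher number from compound 1 to compound 2 (0.09 log units; within the scatter), so compound 2 simply holds the higher of the two numbers without any real separation between them. Compound 3 `N#Cc1ccc(N2CCCc3c(-c4ccncc4)cccc32)cc1C(F)(F)F` is the next member, not yet measured. It differs from compound 2 in one place: pyridin-4-yl in place of 1-methyl-1H-pyrazol-5-yl on an aromatic carbon. Among the measured compounds shown here, the only measured step that bears on this change is the one from compound 1 to compound 2, where a pyridin-3-yl was exchanged for the 1-methyl-1H-pyrazol-5-yl, and it amounted to a 1.2-fold higher number from compound 1 to compound 2 (0.09 log units; within the scatter). Returning to a pyridyl group, now pyridin-4-yl, is therefore expected to give a step of a 1.2-fold lower number from compound 2 to compound 3 (0.06 log units; within the scatter) in this assay, not beyond the scatter. The value estimated for compound 3 in this assay is 8500 nM, within a range of 3500 nM to 20000 nM.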

Compound 3, half-maximal inhibitory concentration: 28700 nM
The estimate for compound 3 lay 3.4-fold (0.53 log units) below the measured number, outside the stated range (above it).
By their numbers in this assay, from the lowest: compounds 1 and 2 (each within the scatter of the next); then compound 3.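

In this assay, the group on this aromatic carbon of the shared core does affect the result: pyridin-4-yl in place of 1-methyl-1H-pyrazol-5-yl gives a 2.9-fold higher number from compound 2 to compound 3 (0.47 log units; beyond the scatter) and this is a modest step, whereas the earlier exchange of pyridin-3-yl for the pyrazolyl group stayed within the scatter. Pyridin-4-yl in place of pyridin-3-yl gives a 3.6-fold higher number from compound 1 to compound 3 (0.56 log units; beyond the scatter) and so shows that the two pyridyl groups are not interchangeable here, although the only change is where the ring nitrogen sits. Nothing measured here accounts for these steps.

As far as these compounds go, whether a plain phenyl ring or a small amine on this carbon would give a lower number than any of these three compounds remains open. Also open, from the compounds shown here alone, is whether the same order of groups would hold if the nitrile or the trifluoromethyl group, common to all three compounds, were replaced.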